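From 1H-tetrazol-5-yl to pyridin-3-yl on compound 3

This account rests on a few compounds, and the source may have more. Where it says the series, first, only, none or still open, it means among the compounds named here.

Of the compounds shown here, three that share one core have been tested in a functional assay on MDA-MB-231 cells (Homo sapiens) for cytotoxicity, read by MTT assay, with a stated time of 24 h; a higher number here means a weaker inhibitor, a lower number a stronger inhibitor. Compound 1 `c1ccc(Oc2ccc(-c3nc4cccnc4n3C3CCCC3)cc2)cc1` gives > 10000 nM, which is a limit of the assay and not a number. Compound 2 `COC(=O)c1ccc(-c2nc3cccnc3n2C2CCCC2)cc1` gives 350 nM, and compound 3 `c1cnc2c(c1)nc(-c1ccc(-c3nnn[nH]3)cc1)n2C1CCCC1` gives 765 nM. For the measured compounds named here, of the two true numbers, the one for compound 3 is the higher, and the gap is modest but beyond the usual scatter: a 2.2-fold higher number from compound 2 to compound 3 (0.34 log units; beyond the scatter).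

Compound 4 `c1cncc(-c2ccc(-c3nc4cccnc4n3C3CCCC3)cc2)c1` carries pyridin-3-yl in place of 1H-tetrazol-5-yl on an aromatic carbon. Going by the values given here, no measured step makes this exact swap, so the guidance is indirect. Phenoxy also holds a six-membered aromatic ring, and replacing it gave two large steps: an at least 28-fold lower number from compound 1 to compound 2 (1.45 log units; beyond the scatter) and an at least 13-fold lower number from compound 1 to compound 3 (1.11 log units; beyond the scatter). Among the compounds with values here, compound 1 is the only example of such a ring here, and pyridin-3-yl is not phenoxy, so only a partial move towards that limit seems reasonable. A modest rise in the number is therefore expected, an estimated 2.0-fold higher number from compound 3 to compound 4 (0.29 log units; within the scatter). For compound 4 the estimated value is 1500 nM, with an expected range from 350 nM to 8000 nM.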

Compound 4, half-maximal inhibitory concentration: > 10000 nM
Compound 4: only a limit was reported; the forecaster's own chance of this, stated with the estimate: 10%; middle value at least 6.6-fold (0.82 log units) from the limit.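

In this assay compound 4 gives > 10000 nM, which is a limit of the assay and not a number. Until now only phenoxy had reached this limit, and pyridin-3-yl, another group with a six-membered aromatic ring, now joins it: the limit of > 10000 nM in this assay, at which 2 of the 4 values shown sit. Measured against the two groups that still give a true number, the change is large both for an aromatic ring, an at least 13-fold higher number from compound 3 to compound 4 (1.11 log units; beyond the scatter), and for a group without one, an at least 28-fold higher number from compound 2 to compound 4 (1.45 log units; beyond the scatter), so among the compounds shown an aromatic ring at this position is not enough to keep a true number, since 1H-tetrazol-5-yl does so while pyridin-3-yl does not.

The step between compound 1 and compound 4 cannot be read, since both values are limits, and phenoxy and pyridin-3-yl therefore cannot be put in order. Still open, going by these compounds, is whether a carboxylic acid, an amine or a five-membered aromatic ring with fewer nitrogen atoms at this position would give a number close to those of compound 2 and compound 3, or would reach the limit as well.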